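Piperidine for ethyl in an open-chain benzophenone amide series

A few compounds are considered here, and "the series" means these few. Any claim that something is new, unique, unknown or untested is made for them only; others in the source may bear on it.

Measured compounds:
compound 1, `CCCC(=O)NCC(=O)N(C)c1ccc(Cl)cc1C(=O)c1ccccc1Cl`, 0.98 mg/kg
compound 2, `NCC(=O)NCC(=O)Nc1ccc([N+](=O)[O-])cc1C(=O)c1ccccc1`, 4.82 mg/kg

Both compounds were tested in a functional assay on the whole organism for antagonist activity, with Mus musculus as the target; a higher number here means that more compound is needed for the effect, a lower number that less compound is needed. Compound 1 gives 0.98 mg/kg, the lower of the two numbers, and compound 2 gives 4.82 mg/kg, a gap that lies beyond the usual scatter. Among the measured compounds shown here, compound 2 differs from compound 1 in several places at once, so the two values show only that compound 1 needs less material than compound 2 for the same effect; no single change can be tied to the gap.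

Compound 3, `CN(C(=O)CNC(=O)CN1CCCCC1)c1ccc(Cl)cc1C(=O)c1ccccc1Cl`, has not yet been measured. It differs from compound 1 at one place only: piperidin-1-yl in place of ethyl on a saturated chain carbon bound to a carbonyl carbon. The change sits on the outer end of the chain, far from the shared core, and brings in a ring with a nitrogen.

For the measured compounds named here, with no single-change step among the measured compounds to lean on, the size of the move is uncertain. A step from compound 1 of a 1.6-fold higher number from compound 1 to compound 3 (0.21 log units; within the scatter) is expected, leaning toward a somewhat higher number but possibly within the scatter. For compound 3 the expected value is 1.6 mg/kg, within the range 0.5 mg/kg to 5 mg/kg.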

Compound 3, dose for half-maximal effect: 7.5 mg/kg
Estimate against measurement, compound 3: 4.7-fold (0.67 log units) below; measured number outside the range, above it.
By their numbers in this assay, from the lowest: compound 1; then compounds 2 and 3 (each within the scatter of the next).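

In this assay the swap of piperidin-1-yl in place of ethyl on a saturated chain carbon bound to a carbonyl carbon gives a 7.7-fold higher number from compound 1 to compound 3 (0.88 log units; beyond the scatter) and so a clear rise in the dose needed for the effect. Among the compounds shown here, this is the first comparison that differs in one place only, and it shows that this position is not indifferent to what sits there: this single change is enough to move the number beyond the usual scatter, which the earlier pair, differing in several places at once, could not show. No measurement at hand gives a reason for this step.

The step alone cannot separate the ring from its nitrogen, and two further groups at the same place would pull these apart: cyclohexyl, with a six-membered ring and no nitrogen, and dimethylamino, with a nitrogen and no ring. It also leaves open how morpholin-4-yl would behave here, and whether a longer chain leading to the piperidin-1-yl would change the result.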